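Vero cytotoxicity notes: from compound 2 toward compound 4

A few compounds are considered here, and "the series" means these few. Any claim that something is new, unique, unknown or untested is made for them only; others in the source may bear on it.

Of the compounds shown here, three have numbers so far in an ADME assay on Vero cells (Chlorocebus sabaeus) for cytotoxicity, read by MTT assay, with a stated time of 72 h; on this read-out lower numbers stand for higher toxicity in this test and higher numbers for lower toxicity in this test. Compound 1 `COc1cc(/C=C/C(=O)c2ccc(OCC(O)CNCCNc3ccnc4cc(Cl)ccc34)cc2)cc(OC)c1OC` gives 1910 nM. Compound 2 `COc1cc(OC)c(OC)cc1/C=C/C(=O)c1ccccc1OCC(=O)NCCNc1ccnc2cc(Cl)ccc12` gives 12300 nM. Compound 3 `O=C(/C=C/c1ccco1)NCCNc1ccnc2cc(Cl)ccc12` gives 629000 nM. Compound 2 thus stands second highest of the three in this assay: compound 1 is its nearest neighbour, with a lower number that lies beyond the scatter, and compound 3 is the furthest, with a higher number that also lies beyond the scatter. Going by the values given here, no pair of these three compounds differs in only one place, so no step between measured compounds can be read off.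

Compound 4 `COc1ccc(/C=C/C(=O)c2ccccc2OCC(=O)NCCNc2ccnc3cc(Cl)ccc23)cc1` remains to be measured in this assay. Its change from compound 2 is 4-methoxyphenyl in place of 2,4,5-trimethoxyphenyl on a double-bonded chain carbon bound to a double-bonded chain carbon. The measured compounds give no direct guide to this change; the shared core and its chain stay as in compound 2. For compound 4 the expected step is a 1.2-fold higher number from compound 2 to compound 4 (0.09 log units; within the scatter), a small one not beyond the scatter, if anything toward a higher number. Compound 4 is therefore estimated at 15000 nM, within a range of 5000 nM to 45000 nM.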

Compound 4, half-maximal cytotoxic concentration: 25000 nM
Compound 4: the middle estimate sits 1.7-fold (0.22 log units) below what was measured; measured number inside the range.
By their numbers in this assay, from the lowest: compound 1; then compound 2; then compound 4; then compound 3.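

In this assay, going by these compounds alone, 4-methoxyphenyl in place of 2,4,5-trimethoxyphenyl on a double-bonded chain carbon bound to a double-bonded chain carbon gives a 2.0-fold higher number from compound 2 to compound 4 (0.31 log units; beyond the scatter), the first step that can be read between compounds differing in one place. The group that enters has fewer heavy atoms and fewer hydrogen-bond acceptors than the group that leaves, yet the step is only modest, so this position shows a real but small response to this change. Nothing measured here bears on the cause of the step.

As far as these compounds go, whether the step comes from one of the methoxy groups that leave or from all of them together stays open. Also open, from the compounds shown here alone, is how the number would respond to a 4-aminophenyl or 4-carboxyphenyl group at this position.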